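Aryl ether series: replacing the piperidine tail with cyclopentyl

A few compounds are considered here, and "the series" means these few. Any claim that something is new, unique, unknown or untested is made for them only; others in the source may bear on it.

compound 1 `Cn1c(=O)c2[nH]c(-c3ccc(OCCCCl)cc3)nc2n(C)c1=O`: in an assay on CHO cells for displacement of a labelled ligand from adenosine receptor A3 (Homo sapiens), read by scintillation counting, with a stated time of 3 h (on this read-out higher numbers stand for weaker inhibition and lower numbers for stronger inhibition), compound 1 gives > 30 nM, a limit of the assay.
compound 2 `Cn1c(=O)c2[nH]c(-c3ccc(OCCC4CCNCC4)cc3)nc2n(C)c1=O`: in this assay compound 2 gives 6.51 nM.

Compound 2 holds the only number shown in this assay; the other value is a limit. Among the compounds with values here, the only measured step is an at least 4.6-fold lower number from compound 1 to compound 2 (0.66 log units; beyond the scatter), and its size is bounded by the limit of > 30 nM in this assay, at which 1 of the 2 values shown sits. Compound 3 `Cn1c(=O)c2[nH]c(-c3ccc(OC4CCCC4)cc3)nc2n(C)c1=O` differs from compound 2 by cyclopentyl in place of 2-(piperidin-4-yl)ethyl on an oxygen on an aromatic ring. This removes the group that an at least 4.6-fold lower number from compound 1 to compound 2 (0.66 log units; beyond the scatter) brought in, so the step of a 6.1-fold higher number from compound 2 to compound 3 (0.79 log units; beyond the scatter) is expected to run toward weaker inhibition, beyond the scatter, with a limit possible. Compound 3 is estimated at 40 nM in this assay, range 10 nM to 200 nM.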

Compound 3, inhibition constant: > 10 nM
Compound 3: no number, only a limit; the forecaster's own chance of this, stated with the estimate: 45%; the middle value is on the limit's open side.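

In this assay compound 3 gives only a limit, so the cyclopentyl ether has no number of its own: the limit of > 10 nM in this assay, at which 1 of the 3 values shown sits.
Cyclopentyl in place of 2-(piperidin-4-yl)ethyl on this oxygen gives an at least 1.5-fold higher number from compound 2 to compound 3 (0.18 log units; that floor lies within the scatter), so the change is not shown to weaken inhibition. The step from compound 1 to compound 3 cannot be read, as both values are limits.

Still open, from the compounds shown here alone, is whether the gain in compound 2 depends on the piperidine nitrogen or on the length of the chain. A 2-cyclopentylethyl or a 2-aminoethyl group on the same oxygen would separate these two.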